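Working notes: from compound 2 to compound 4

The source may report more compounds than this note shows. Statements on the series, on what has been measured and on what is new or still open speak of the compounds shown alone.

Values in a physicochemical assay for lipophilicity, measured as octanol-water partition (on this read-out higher numbers stand for higher lipophilicity and lower numbers for lower lipophilicity), so far:
- compound 1 `CCOc1ccc(/C=N/NC(=O)COc2cccc3ccccc23)cc1O` gives 3.82
- compound 2 `O=C(COc1cccc2ccccc12)N/N=C/c1cccc(O)c1` gives 3.73
- compound 3 `O=C(COc1cccc2ccccc12)N/N=C/c1cccc([N+](=O)[O-])c1` gives 3.97

Compound 2 stands within the scatter of both other compounds (a number 0.09 log units lower from compound 1 to compound 2 (within the scatter)). The next structure is compound 4 `CSc1ccc(/C=N/NC(=O)COc2cccc3ccccc23)cc1`, not yet measured in this assay, and the change is this: 4-(methylsulfanyl)phenyl in place of 3-hydroxyphenyl on a carbon with a double bond to nitrogen. Among the compounds with values here, two measured steps bear on it, and both stayed within the scatter. The closer guide is the exchange of hydroxy for nitro (a number 0.24 log units higher from compound 2 to compound 3 (within the scatter)). Neither step brings in 4-(methylsulfanyl)phenyl, so the guidance is rough. Expected is an upward step somewhat larger than that one (a number 0.47 log units higher from compound 2 to compound 4 (beyond the scatter)). For compound 4 the expected value is 4.2, with an estimated range from 3.85 to 4.55.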

Compound 4, partition coefficient: 4.11
Estimate against measurement, compound 4: 0.09 log units above, within the range that was stated.
By their numbers in this assay, from the lowest: compounds 2, 1, 3 and 4 (each within the scatter of the next, the first and the last beyond it).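

In this assay, 4-(methylsulfanyl)phenyl in place of 3-hydroxyphenyl on a carbon with a double bond to nitrogen gives a number 0.38 log units higher from compound 2 to compound 4 (beyond the scatter), the only step shown so far that lies beyond the scatter. The exchange alters both the substituent and its place on the ring, so these two changes cannot be separated. No measurement bears on why the number moves. Going by these compounds, it remains open how much of the step belongs to the methylsulfanyl group and how much to the departure of hydroxy. On these data alone, it is also open how an amine or a carboxylic acid on this ring would read.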